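The source may hold more compounds than are shown below. What is called first, only, known or untested is meant among the compounds shown, and "the series" means these compounds.

Compound 1, `CC(C)C(c1nnc[nH]1)c1ccc(-c2ccc3cccc(F)c3c2)[nH]c1=O`: 0.905 h in an ADME assay on microsomes from liver (Homo sapiens) for metabolic stability; on this read-out higher numbers stand for a longer-lived compound and lower numbers for a shorter-lived compound.
Compound 2, `CC(C)C(/C=C1\CCNC1=O)c1ccc(-c2ccc3cccc(F)c3c2)[nH]c1=O`: 0.713 h in this assay.
Compound 3, `CC(C)C(c1ncco1)c1ccc(-c2ccc3cccc(F)c3c2)[nH]c1=O`: 0.178 h in this assay.

Of these three, compound 3 sits lowest: one step is a 4.0-fold lower number from compound 2 to compound 3 (0.60 log units; beyond the scatter) and the other is a 5.1-fold lower number from compound 1 to compound 3 (0.71 log units; beyond the scatter), both beyond the scatter, whereas a 1.3-fold lower number from compound 1 to compound 2 (0.10 log units; within the scatter) lies within it. The unmeasured compound 4, `CC(C)C(Nc1nnc[nH]1)c1ccc(-c2ccc3cccc(F)c3c2)[nH]c1=O`, differs from compound 3 in a single place: (4H-1,2,4-triazol-3-yl)amino in place of 1,3-oxazol-2-yl on a saturated chain carbon bound to an aromatic carbon and a saturated chain carbon. The measured step that bears most directly on this change is a 5.1-fold lower number from compound 1 to compound 3 (0.71 log units; beyond the scatter), since compound 1 carries the same 4H-1,2,4-triazol-3-yl group that enters here, though it sits directly on the saturated chain carbon rather than through an amino group. Among the compounds with values here, no measured pair shows what the amino group alone does, so the expectation rests on the triazole comparison and carries a wider uncertainty than that single step would suggest. The step from compound 3 to compound 4 is expected to be a 3.9-fold higher number from compound 3 to compound 4 (0.59 log units; beyond the scatter), a rise roughly undoing the drop seen from compound 1 to compound 3. Compound 4 is therefore estimated at 0.7 h in this assay, with a range from 0.3 h to 1.6 h.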

Compound 4, half-life: > 3 h
Compound 4 gave a limit, no number; the forecaster's own chance of this, stated with the estimate: 5%; at least 4.2-fold (0.63 log units) between middle value and limit.
By their numbers in this assay, from the lowest: compound 3; then compounds 2 and 1 (each within the scatter of the next). At a limit, above all of these: compound 4.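

Compound 4 stands at a limit of this assay, not at a number: the limit of > 3 h in this assay, at which 1 of the 4 values shown sits.

With the 4H-1,2,4-triazol-3-yl ring present on both sides, the added amino group on the saturated chain carbon goes with an at least 3.3-fold higher number from compound 1 to compound 4 (0.52 log units; beyond the scatter), so the triazole ring alone does not account for this result, a separation that none of the earlier compounds could offer. Set against the other groups at this place, (4H-1,2,4-triazol-3-yl)amino gives an at least 16-fold higher number from compound 3 to compound 4 (1.22 log units; beyond the scatter) and an at least 4.2-fold higher number from compound 2 to compound 4 (0.62 log units; beyond the scatter), which shows that the read-out at this place reaches well past the spread of the first three compounds.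

The compounds shown leave open whether the amino link would do the same for another ring, such as 1,3-oxazol-2-yl, and whether an ether oxygen or a methylene in place of the amino nitrogen would keep the gain. They also leave open what in this change lies behind the rise, and whether a methyl group on the amino nitrogen would hold it in this assay.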